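A few compounds are considered here, and "the series" means these few. Any claim that something is new, unique, unknown or untested is made for them only; others in the source may bear on it.

Working notes on the series. Going by the values given here, compound 1 `COc1ccccc1C(=O)NC(=O)Nc1ccc(-c2ccccc2)c(C(F)(F)F)c1` gives 23 ug/mL in a physicochemical assay for solubility, in simulated intestinal fluid (a lower number here means a less soluble compound, a higher number a more soluble compound), the second highest of the three numbers so far. Compound 2 `COc1ccccc1C(=O)NC(=O)Nc1ccc(-c2ccccc2)c(C(C)C)c1`, with isopropyl in place of trifluoromethyl on an aromatic carbon, gives 24 ug/mL; the change a 1.0-fold higher number from compound 1 to compound 2 (0.02 log units; within the scatter) stays within the scatter. Among the compounds with values here, compound 3 `COc1ccccc1C(=O)NC(=O)Nc1ccc(OCC(F)(F)F)c(C(F)(F)F)c1`, with 2,2,2-trifluoroethoxy in place of phenyl on an aromatic carbon, gives 2.2 ug/mL; the change a 10-fold lower number from compound 1 to compound 3 (1.02 log units; beyond the scatter) is the one large step seen. Both measured steps alter the aniline side of the shared core; the acyl side is untouched in all three.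

Compound 4 `COc1ccncc1C(=O)NC(=O)Nc1ccc(-c2ccccc2)c(C(F)(F)F)c1` differs from compound 1 only on that acyl side: 4-methoxypyridin-3-yl in place of 2-methoxyphenyl on a carbonyl carbon. Within the data shown here, no measured step bears on this change, so the expectation rests on the value of compound 1 alone, with the two measured steps serving only to show how wide the spread in this assay can run. The expected step of a 1.4-fold higher number from compound 1 to compound 4 (0.14 log units; within the scatter) is small, within or only just beyond the scatter, and if anything upward. Compound 4 is estimated at 32 ug/mL, within 12 ug/mL to 85 ug/mL.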

Compound 4, solubility: 16 ug/mL
Compound 4: the middle estimate sits 2.0-fold (0.30 log units) above what was measured; measured number inside the range.
By their numbers in this assay, from the lowest: compound 3; then compounds 4, 1 and 2 (each within the scatter of the next).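

The acyl side now has its first measured step: in this assay, 4-methoxypyridin-3-yl in place of 2-methoxyphenyl on a carbonyl carbon gives a 1.4-fold lower number from compound 1 to compound 4 (0.16 log units; within the scatter), so this exchange of a ring carbon for a ring nitrogen leaves the number within the scatter. Going by these compounds alone, on the background of compound 1, this change therefore stands apart from the one large step so far, a 10-fold lower number from compound 1 to compound 3 (1.02 log units; beyond the scatter), which lies on the aniline side. No measurement at hand offers a reason for this outcome.

As far as these compounds go, whether the same exchange stays within the scatter on the background of compound 3, the lowest of the series, remains open. Also open, from the compounds shown here alone, is how this assay would read with a morpholine or a carboxylic acid in place of the methoxy group of 4-methoxypyridin-3-yl.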